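Bromo in Place of Methyl: Compound 3 to Compound 4

The source may report more compounds than this note shows. Statements on the series, on what has been measured and on what is new or still open speak of the compounds shown alone.

Compound 3 `Cc1ccc(-c2nn(-c3ccccc3)cc2CNc2ccc(Cl)cc2)cc1` is one of three measured compounds, alongside compound 1 `Cc1ccc(-c2nn(-c3ccccc3)cc2CNc2ccc(F)cc2)cc1` and compound 2 `Cc1ccc(-c2nn(-c3ccccc3)cc2CNc2ccc(Br)cc2)cc1`. In a functional assay on MCF7 cells (Homo sapiens) for antiproliferative activity, read by MTT assay, with a stated time of 48 h (a lower number here means a stronger inhibitor, a higher number a weaker inhibitor), compound 1 gives 5880 nM, compound 2 gives 6890 nM and compound 3 gives 6020 nM. Compound 3 stands second highest of the three numbers, nearest to compound 1 and furthest from compound 2, yet every gap lies within the scatter: a 1.2-fold higher number from compound 1 to compound 2 (0.07 log units; within the scatter), a 1.0-fold higher number from compound 1 to compound 3 (0.01 log units; within the scatter) and a 1.1-fold lower number from compound 2 to compound 3 (0.06 log units; within the scatter). Compound 4 `Clc1ccc(NCc2cn(-c3ccccc3)nc2-c2ccc(Br)cc2)cc1` differs from compound 3 by bromo in place of methyl on an aromatic carbon. Among the compounds with values here, none of the measured steps touches this place; each of them exchanges one halogen for another elsewhere in the structure, and each stayed within the scatter. Within the data shown here, there is thus no direct precedent for the methyl-to-bromo exchange, and the only guide is that small substituent exchanges on an aromatic carbon in this set left the numbers essentially unchanged. Compound 4 is therefore expected to show a step of about a 1.0-fold lower number from compound 3 to compound 4 (0.00 log units; within the scatter), no larger than the scatter. The estimate for compound 4 is 6000 nM, between 3000 nM and 12000 nM.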

Compound 4, half-maximal inhibitory concentration: 4150 nM
For compound 4 the middle estimate is 1.4-fold (0.16 log units) above the measured one; measured number inside the range.
By their numbers in this assay, from the lowest: compounds 4, 1, 3 and 2 (each within the scatter of the next).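

In this assay, bromo in place of methyl on the aromatic carbon para to a large group gives a 1.5-fold lower number from compound 3 to compound 4 (0.16 log units; within the scatter), so this first reading at this place shows no change beyond the scatter. The earlier steps shown here exchanged only one halogen for another at a different place, and this result extends the same finding to a second place and to an exchange of methyl for a halogen. Nothing available explains the size or direction of this step.

The compounds shown leave open whether a markedly different group at this position, such as an amine, a carboxylic acid or a longer chain, would move the number beyond the scatter. They also leave open whether bromo here would give a similar number with fluoro in place of the chloro that compound 4 carries at the other halogen site.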